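This account rests on a few compounds, and the source may have more. Where it says the series, first, only, none or still open, it means among the compounds named here.

Measured in a functional assay on A549 cells (Homo sapiens) for cytotoxicity, read by MTT assay, with a stated time of 72 h; a lower number here means a stronger inhibitor, a higher number a weaker inhibitor:
compound 1 `Cn1ccc2c(Oc3ccc(NC(=O)c4cc5cccnc5n(-c5ccccc5)c4=O)cc3F)ncnc21`: 63200 nM
compound 2 `Cn1ccc2c(Oc3ccc(NC(=O)c4cc5cccnc5n(-c5ccc(C(F)(F)F)c(Cl)c5)c4=O)cc3F)ncnc21`: 320000 nM
compound 3 `O=C(Nc1ccc(Oc2ncnc3[nH]ccc23)c(F)c1)c1cc2cccnc2n(-c2ccccc2)c1=O`: 45500 nM

Compound 3 stands level with compound 1, since a 1.4-fold lower number from compound 1 to compound 3 (0.14 log units; within the scatter) is a step within the scatter, and the value of compound 3 is well under that of compound 2. Compound 4 `O=C(Nc1ccc(Oc2ncnc3[nH]ccc23)c(F)c1)c1cc2cccnc2n(-c2ccc(Br)cc2)c1=O` differs from compound 3 by bromo in place of hydrogen on an aromatic carbon, which turns phenyl into 4-bromophenyl. For the measured compounds named here, the only measured change to that phenyl is the one to 3-chloro-4-(trifluoromethyl)phenyl, a 5.1-fold higher number from compound 1 to compound 2 (0.70 log units; beyond the scatter). Bromo alone is a smaller change, so a small upward step in this assay is expected, not clearly beyond the scatter. The expected step is a 1.8-fold higher number from compound 3 to compound 4 (0.25 log units; within the scatter). For compound 4 the estimate is 80000 nM, with an expected range from 30000 nM to 210000 nM.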

Compound 4, half-maximal inhibitory concentration: 27300 nM
For compound 4 the middle estimate is 2.9-fold (0.47 log units) above the measured one; the measured number lies below the stated range.
By their numbers in this assay, from the lowest: compounds 4, 3 and 1 (each within the scatter of the next, the first and the last beyond it); then compound 2.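

In this assay, bromo on an aromatic carbon of the phenyl, para to a large group, gives a step within the scatter: a 1.7-fold lower number from compound 3 to compound 4 (0.22 log units; within the scatter). Adding a substituent to this phenyl therefore does not by itself bring the upward step seen with 3-chloro-4-(trifluoromethyl)phenyl, a 5.1-fold higher number from compound 1 to compound 2 (0.70 log units; beyond the scatter), although that step comes from the compounds with methyl on the aromatic nitrogen. No available evidence bears on this result. Going by these compounds, whether an amine or a carboxylic acid at this place would also stay within the scatter remains open, as does whether chloro or trifluoromethyl alone accounts for that upward step.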